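Replacing a dibromopyridine with a methoxypyridine on the sulfonamide

This account rests on a few compounds, and the source may have more. Where it says the series, first, only, none or still open, it means among the compounds named here.

Compound 1: `O=S(=O)(CSc1nnc(Br)n1Cc1ccc(Br)c2ccccc12)Nc1cccnc1Br`, 280 nM
Compound 2: `O=S(=O)(CSc1nnc(Br)n1Cc1ccc(Br)c2ccccc12)Nc1ccc(Br)nc1Br`, 5410 nM

In an assay on HEK293 cells for inhibition of solute carrier family 22 member 12 (Homo sapiens) (on this read-out higher numbers stand for weaker inhibition and lower numbers for stronger inhibition), compound 2 holds the higher of these two numbers; compound 1 is the nearest, separated by a 19-fold higher number from compound 1 to compound 2 (1.29 log units; beyond the scatter). Compound 3 `COc1ncccc1NS(=O)(=O)CSc1nnc(Br)n1Cc1ccc(Br)c2ccccc12` carries 2-methoxypyridin-3-yl in place of 2,6-dibromopyridin-3-yl on a sulfonamide nitrogen. Among the compounds with values here, only that one measured step bears on this change: it brought in one of the two bromines, and undoing it should lower the number again. The exchange of the other bromine for methoxy is not covered by any measured pair. Compound 3 is therefore estimated at 450 nM, within 120 nM to 2000 nM, a step of a 12-fold lower number from compound 2 to compound 3 (1.08 log units; beyond the scatter) expected.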

Compound 3, half-maximal inhibitory concentration: 4050 nM
Beside the measured number, compound 3's estimate is 9.0-fold (0.95 log units) below it; the measured number lies above the stated range.
By their numbers in this assay, from the lowest: compound 1; then compounds 3 and 2 (each within the scatter of the next).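

In this assay, 2-methoxypyridin-3-yl in place of 2,6-dibromopyridin-3-yl on the sulfonamide nitrogen gives a 1.3-fold lower number from compound 2 to compound 3 (0.13 log units; within the scatter) and so leaves the two compounds indistinguishable. Methoxy in place of bromo on the aromatic carbon gives a 14-fold higher number from compound 1 to compound 3 (1.16 log units; beyond the scatter) and shows that this carbon responds strongly to the group it carries, even without the second bromine. No evidence here explains either step. Still open, as far as these compounds go, is how a smaller group, such as chloro, fluoro or an amine, on that same carbon would compare with bromo and methoxy.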